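The compounds below may be only part of what the source reports. "The series", "measured", "known", "first", "only" and "open" are said of these compounds alone.

Compound 1, `O=C(NO)c1ccc(NCc2nc(-c3cccnc3)nn2-c2ccccc2)cc1`, gives 57.7% in an assay on Sf9 cells for inhibition of protein deacetylase HDAC6 (Homo sapiens), read by fluorescence, with a stated time of 40 min, tested at 100 nM; on this read-out higher numbers stand for more inhibition at the one concentration tested (going by the name of the read-out) and lower numbers for less inhibition.
Compound 2, `O=C(NO)c1ccc(NCc2nc(-c3ccc(Cl)cc3)nn2-c2ccccc2)cc1`, gives 67.2% in this assay.

On these two numbers compound 2 and compound 1 lie within the scatter of each other, so neither can be ranked above the other. Compound 3, `O=C(NO)c1ccc(NCc2nc(-c3cc4ccccc4s3)nn2-c2ccccc2)cc1`, differs from compound 2 by 1-benzothiophen-2-yl in place of 4-chlorophenyl on an aromatic carbon. Among the measured compounds shown here, the only step that bears on this position is a number 9.5 percentage points higher from compound 1 to compound 2 (within the scatter), and it was within the scatter. On that basis the expected change is a number 0.8 percentage points higher from compound 2 to compound 3 (within the scatter), that is, no movement beyond the scatter. Compound 3 is therefore estimated at 68%, within 48% to 85%.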

Compound 3, a percentage reported as inhibition, at one concentration (the size of the read-out at that concentration, not a potency): 65.5%
Beside the measured number, compound 3's estimate is 2.5 percentage points above it; the range from low to high includes it.
By their numbers in this assay, from the lowest: compounds 1, 3 and 2 (each within the scatter of the next).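

In this assay the position on the aromatic carbon between two ring nitrogen atoms now also carries a fused two-ring group: 1-benzothiophen-2-yl gives a number 1.7 percentage points lower from compound 2 to compound 3 (within the scatter) in place of 4-chlorophenyl, and a number 7.8 percentage points higher from compound 1 to compound 3 (within the scatter) in place of pyridin-3-yl. All three groups at this position therefore read alike, and the larger group shifts the number by no more than the scatter. No evidence is available that would explain this result.

From the compounds shown here alone, whether an amine or a carboxylic acid at this carbon would move the number beyond the scatter remains open.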